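This account rests on a few compounds, and the source may have more. Where it says the series, first, only, none or still open, it means among the compounds named here.

Working notes on the series.

Compound 1 `CSc1nc(N)c2nc(O)n(Cc3ccccc3)c2n1` is the reference point. In a functional assay (spleen, spleen) for activation, with Mus musculus as the target (a lower number here means that less compound is needed, a higher number that more compound is needed for the effect), compound 1 gives 0.1 uM, the lowest of the two numbers in hand. Compound 3 `COc1ccccc1Cn1c(O)nc2c(N)ncnc21` gives 10 uM in this assay, a gap to compound 1 that lies well beyond the scatter. Compound 2 `CSc1nc2c(N)ncnc2n1Cc1ccccc1` reaches only the limit of > 10 uM in this assay, at which 1 of the 3 values shown sits, in this assay, a limit rather than a number; for compound 2 the value > 10 uM should be read as that limit.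

Compound 4 `COc1nc(N)c2nc(O)n(Cc3ccccc3)c2n1` differs from compound 1 in one place: methoxy in place of methylsulfanyl on an aromatic carbon. Going by the values given here, no pair among the measured compounds differs in one place, so no measured step guides this change. The expectation is a small shift toward a higher number, of a size that may or may not clear the scatter, as the step of a 3.0-fold higher number from compound 1 to compound 4 (0.48 log units; beyond the scatter) is estimated. For compound 4 the estimated value in this assay is 0.3 uM, with a range from 0.05 uM to 2 uM.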

Compound 4, minimum effective concentration: 0.1 uM
The estimate for compound 4 lay 3.0-fold (0.48 log units) above the measured number, and the stated range covers the measured number.
By their numbers in this assay, from the lowest: compounds 1 and 4 (each within the scatter of the next); then compound 3.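

In this assay the series now has its first step that changes a single place, no change at the digits printed from compound 1 to compound 4 (within the scatter), with methoxy in place of methylsulfanyl on an aromatic carbon between two ring nitrogen atoms. The sulfur of methylsulfanyl is therefore not required at this position for the number seen with the core of compound 1, since compound 4 gives 0.1 uM with oxygen in its place. Compound 2 and compound 3 differ from compound 1 in more than one place, so neither could show this.

As far as these compounds go, whether a group of another kind at this position, such as an amine or a longer chain like butoxy, would hold the number remains open. Nothing in hand speaks to why methoxy and methylsulfanyl read alike here.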